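The source may report more compounds than this note shows. Statements on the series, on what has been measured and on what is new or still open speak of the compounds shown alone.

In a functional assay on CCRF-CEM cells (Homo sapiens) for inhibition, read by cell counting, with a stated time of 72 h (on this read-out lower numbers stand for stronger inhibition and higher numbers for weaker inhibition), compound 1 `CCN(CC)CN1C(=O)/C(=N/NC(=S)Nc2ccc(Cl)cc2)c2ccccc21` gives 10000 nM, and compound 2 `CCN(CC)CN1C(=O)/C(=N/NC(=S)Nc2ccc(C)cc2)c2cc(Cl)ccc21` gives 4600 nM. Compound 1 therefore holds the higher of the two numbers, making it the weaker inhibitor of this pair, and the gap is larger than the usual scatter between repeat measurements. These two compounds differ in more than one place, so their gap cannot be tied to any single change.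

Compound 3 `CCN(CC)CN1C(=O)/C(=N/NC(N)=S)c2ccccc21` has not yet been measured. It has hydrogen in place of 4-chlorophenyl on an amide-type nitrogen, compared with compound 1: hydrogen in place of 4-chlorophenyl on an amide-type nitrogen. Within the data shown here, no measured pair isolates this change, so any forecast is a judgement with wide uncertainty. Neither measured compound lacks a six-membered aromatic ring at this place, and compound 1 is already weak at 10000 nM. A moderate move toward a higher number, meaning weaker inhibition and probably just beyond the scatter, is therefore expected. The expected size of this move is a 2.0-fold higher number from compound 1 to compound 3 (0.30 log units; within the scatter). For compound 3, the estimated value is 20000 nM, with an expected range of 7000 nM to 60000 nM.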

Compound 3, half-maximal inhibitory concentration: 164000 nM
Beside the measured number, compound 3's estimate is 8.2-fold (0.91 log units) below it, and the stated range ends below it.
By their numbers in this assay, from the lowest: compound 2; then compound 1; then compound 3.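

In this assay, among these compounds, replacing 4-chlorophenyl with hydrogen on the amide-type nitrogen gives a 16-fold higher number from compound 1 to compound 3 (1.21 log units; beyond the scatter), a large step well beyond the scatter and the first change in this set that can be read at a single place. It shows that this position is far from neutral: even though compound 1 is a weak inhibitor, a substantial part of the inhibition it does show is lost when its (4-chlorophenyl)amino end is cut back to a plain amino end. No measurement here bears on why the loss is so large.

Going by these compounds, a single step cannot separate the contribution of the six-membered aromatic ring from that of its chlorine, so it remains open whether an unsubstituted phenyl group on this nitrogen would keep the number close to that of compound 1. On these data alone, it is equally open whether a non-aromatic group, such as a cyclohexyl ring or a short chain like ethyl, would recover any of the inhibition that disappears with hydrogen.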